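Swapping Bromophenyl for Dichlorophenyl in an H1 Antagonist Series

The source may hold more compounds than are shown below. What is called first, only, known or untested is meant among the compounds shown, and "the series" means these compounds.

Measured so far:
Compound 1 `CCOC(=O)N/C(=N\CCC(c1ccc(F)cc1)c1ccccn1)NCCCc1c[nH]cn1` gives 5.3 in a functional assay on ileum for antagonist activity at histamine H1 receptor (Cavia porcellus); on this read-out lower numbers stand for lower potency and higher numbers for higher potency (the scale is a negative logarithm).
Compound 2 `N=C(NCCCc1c[nH]cn1)NCCC(c1ccccc1)c1ccccn1` gives 7.01 in this assay.
Compound 3 `N=C(NCCCc1c[nH]cn1)NCCC(c1ccc(Br)cc1)c1ccccn1` gives 6.92 in this assay.

Compound 3 stands second highest of the three numbers; compound 2 is its nearest neighbour, within the usual scatter, while compound 1 sits far below it, beyond the scatter. Compound 4 `N=C(NCCCc1c[nH]cn1)NCCC(c1ccc(Cl)c(Cl)c1)c1ccccn1` differs from compound 3 by 3,4-dichlorophenyl in place of 4-bromophenyl on a saturated chain carbon bound to an aromatic carbon and a saturated chain carbon. For the measured compounds named here, the only measured step that touches this change is a number 0.09 log units lower from compound 2 to compound 3 (within the scatter), where a halogen entering the same phenyl ring left the number essentially unchanged. On that single precedent, compound 4 is expected to show a number 0.02 log units lower from compound 3 to compound 4 (within the scatter), no movement beyond the scatter. Compound 4 is therefore estimated at 6.9, between 6.4 and 7.4.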

Compound 4, negative logarithm of the antagonist equilibrium constant: 7.1
The estimate for compound 4 lay 0.20 log units below the measured number, within the range that was stated.
By their numbers in this assay, from the lowest: compound 1; then compounds 3, 2 and 4 (each within the scatter of the next).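

In this assay the swap from 4-bromophenyl to 3,4-dichlorophenyl gives a number 0.18 log units higher from compound 3 to compound 4 (within the scatter) and the swap from phenyl to 3,4-dichlorophenyl gives a number 0.09 log units higher from compound 2 to compound 4 (within the scatter) on the same carbon. This position therefore takes a ring with two chlorines as well as one with a single bromine or none, with no step beyond the scatter. Nothing available explains this tolerance.

Still open, from the compounds shown here alone, is how a phenyl ring carrying a methoxy group, an amine or a carboxylic acid would read at this position.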